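The compounds below may be only part of what the source reports. "The series", "measured", "known", "first", "only" and "open" are said of these compounds alone.

The series shares one core and is varied on a double-bonded chain carbon bound to a double-bonded ring carbon. Compound 1 `CN(C)c1ccc(C=C2C(=O)N(c3ccc(Cl)cc3)N(c3ccc(Cl)cc3)C2=O)cc1` carries a 4-(dimethylamino)phenyl there. In a functional assay on SMMC-7721 cells (Homo sapiens) for cytotoxicity, read by MTT assay, with a stated time of 72 h (on this read-out lower numbers stand for stronger inhibition and higher numbers for weaker inhibition), compound 1 gives only a limit of the assay, > 128000 nM. Among the three measured compounds, compound 1 is the one that sits at the limit of > 128000 nM in this assay, at which 1 of the 3 values shown sits. Compound 2 `O=C1C(=Cc2ccc(F)cc2)C(=O)N(c2ccc(Cl)cc2)N1c1ccc(Cl)cc1` gives 23300 nM in this assay. Compound 3 `O=C1C(=Cc2cccc(Cl)c2)C(=O)N(c2ccc(Cl)cc2)N1c1ccc(Cl)cc1` gives 20200 nM in this assay. The step of an at least 5.4-fold lower number from compound 1 to compound 2 (0.73 log units; beyond the scatter) and the step of an at least 6.3-fold lower number from compound 1 to compound 3 (0.80 log units; beyond the scatter) both move away from the limit of compound 1, while the step of a 1.2-fold lower number from compound 2 to compound 3 (0.06 log units; within the scatter) shows that the two replacements land together.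

Compound 4 `O=C1C(=Cc2c[nH]c3ccccc23)C(=O)N(c2ccc(Cl)cc2)N1c1ccc(Cl)cc1` is not yet measured. It differs from compound 1 by 1H-indol-3-yl in place of 4-(dimethylamino)phenyl on a double-bonded chain carbon bound to a double-bonded ring carbon. Both measured steps from compound 1 bear on this change, since each also swaps the group at the same place, and both were at least modest and in the same direction. Compound 4 is therefore expected to give a number clear of the limit of compound 1, a step estimated as an at least 6.4-fold lower number from compound 1 to compound 4 (0.80 log units; beyond the scatter). For compound 4 the estimate in this assay is 20000 nM, with a range from 5000 nM to 90000 nM.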

Compound 4, half-maximal inhibitory concentration: 19600 nM
Compound 4: the middle estimate sits 1.0-fold (0.01 log units) above what was measured; low and high end bracket the measured number.
By their numbers in this assay, from the lowest: compounds 4, 3 and 2 (each within the scatter of the next). At a limit, above all of these: compound 1.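

In this assay, the 1H-indol-3-yl of compound 4 shows that this place on the double-bonded chain carbon also takes a group with a five-membered aromatic ring and a hydrogen-bond donor, and the change from 4-(dimethylamino)phenyl gives an at least 6.5-fold lower number from compound 1 to compound 4 (0.81 log units; beyond the scatter). Compound 4 does not separate from the single-ring groups, with a 1.0-fold lower number from compound 3 to compound 4 (0.01 log units; within the scatter) and a 1.2-fold lower number from compound 2 to compound 4 (0.08 log units; within the scatter), so 1H-indol-3-yl, 3-chlorophenyl and 4-fluorophenyl now land together in this assay, and the set holds one outlying compound rather than a graded order. Compound 1 remains the only compound held at a limit of the assay: the limit of > 128000 nM in this assay, at which 1 of the 4 values shown sits.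

That limit leaves the full size of every step from compound 1 unknown, and the compounds shown do not tell whether the dimethylamino group alone sets compound 1 apart, which a primary amine or a methoxy group in its place would test. They also leave open whether the hydrogen on the indole nitrogen contributes anything, which an indole with a methyl on that nitrogen would address.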